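Chloro to methoxy exchange: expected cytotoxicity of compound 4

The compounds below may be only part of what the source reports. "The series", "measured", "known", "first", "only" and "open" are said of these compounds alone.

Compound 1 `N=C(N)c1ccc(-c2cc(-c3cccc(C(=N)N)c3Cl)on2)cc1` and compound 2 `COc1c(C(=N)N)cccc1-c1cc(-c2ccc(C(=N)N)cc2)no1` share one core; compound 3 `N=C(N)c1cccc(-c2cc(-c3cccc(C(=N)N)c3Cl)on2)c1` has the same atoms joined differently, and the difference between the two cores is not broken down here. In an ADME assay on L6 cells (Rattus norvegicus) for cytotoxicity (on this read-out lower numbers stand for stronger inhibition and higher numbers for weaker inhibition), compound 1 gives 71400 nM, compound 2 gives 52800 nM and compound 3 gives 109000 nM. The change from compound 1 to compound 2, (methoxy in place of chloro on an aromatic carbon), made a 1.4-fold lower number from compound 1 to compound 2 (0.13 log units; within the scatter). Compound 4 `COc1c(C(=N)N)cccc1-c1cc(-c2cccc(C(=N)N)c2)no1` is related to compound 3 by the same change, (methoxy in place of chloro on an aromatic carbon), at a place described identically. Compound 3 and compound 1 lie within the scatter of each other, while compound 3 sits higher than compound 2 by a margin beyond it. Among the measured compounds shown here, for compound 4 the step from compound 3 is expected to be a 1.4-fold lower number from compound 3 to compound 4 (0.13 log units; within the scatter), resting only on the single earlier step of a 1.4-fold lower number from compound 1 to compound 2 (0.13 log units; within the scatter). Compound 4 is therefore estimated at 80000 nM, between 45000 nM and 160000 nM.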

Compound 4, half-maximal inhibitory concentration: 125000 nM
Estimate against measurement, compound 4: 1.6-fold (0.19 log units) below; measured number inside the range.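

In this assay, methoxy in place of chloro on an aromatic carbon gave a 1.1-fold higher number from compound 3 to compound 4 (0.06 log units; within the scatter). This step does not differ from the earlier one: the same change on two cores in this assay, a 1.4-fold lower number (0.13 log units; within the scatter) from compound 1 to compound 2 and a 1.1-fold higher number (0.06 log units; within the scatter) from compound 3 to compound 4, 1.6-fold (0.19 log units) apart, within the scatter of two such steps. Across these two cores the change thus leaves the number within the scatter, but two small steps cannot separate a slight effect from none and say nothing about other cores.

The compounds shown carry only chloro or methoxy on this aromatic carbon, so the outcome with fluoro, hydroxyl or a longer alkoxy chain there remains open. Also open, as far as these compounds go, is whether the step stays this small when an amidine group elsewhere in the molecule gives way to an amine.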